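Bromo in Place of Chloro: One Measured Pair, One Prediction

The compounds below may be only part of what the source reports. "The series", "measured", "known", "first", "only" and "open" are said of these compounds alone.

Compound 2 `Cc1[nH]c2ccc(Cl)cc2c(=O)c1Br` and compound 1 `Cc1[nH]c2ccc(Br)cc2c(=O)c1Br` share one core and differ only by bromo in place of chloro on an aromatic carbon. In an ADME assay for permeability, using PAMPA, at pH 4 (a lower number here means that the compound crosses the layer more slowly, a higher number that the compound crosses the layer faster), compound 2 gives 84.5 10^-6 cm/s, while compound 1 gives 133 10^-6 cm/s, so that change made a 1.6-fold higher number from compound 2 to compound 1 (0.20 log units; within the scatter). Compound 3 `CCc1c(C)[nH]c2cc(OC)c(Cl)cc2c1=O` is built on another core; the difference between the two cores is not broken down here. In this assay compound 3 gives 96.4 10^-6 cm/s. Compound 4 `CCc1c(C)[nH]c2cc(OC)c(Br)cc2c1=O` differs from compound 3 by bromo in place of chloro on an aromatic carbon. This is the same kind of change as before, though in compound 3 and compound 4 the place is ortho to a methoxy group (2 heavy atoms), which is not so for compound 2 and compound 1. Compound 4 is expected to give 125 10^-6 cm/s, in a range of 75 10^-6 cm/s to 210 10^-6 cm/s, because the same kind of change gave a 1.6-fold higher number from compound 2 to compound 1 (0.20 log units; within the scatter). The expected step is a 1.3-fold higher number from compound 3 to compound 4 (0.11 log units; within the scatter).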

Compound 4, apparent permeability: 81.9 10^-6 cm/s
Compound 4: middle estimate off by 1.5-fold (0.18 log units), on the high side; the measured number falls inside the stated range.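

In this assay, bromo in place of chloro gives a 1.2-fold lower number from compound 3 to compound 4 (0.07 log units; within the scatter), so on this core the swap cannot be told apart from the ordinary spread of repeated measurements. Set beside the earlier step, the result gives no sign that the two cores respond differently: the same change on two cores in this assay, a 1.6-fold higher number (0.20 log units; within the scatter) from compound 2 to compound 1 and a 1.2-fold lower number (0.07 log units; within the scatter) from compound 3 to compound 4, 1.9-fold (0.27 log units) apart, within the scatter of two such steps This shows only that both steps are too small to read, not that the change carries over identically, as two steps within the scatter can neither confirm nor exclude a small real difference between the cores.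

The compounds shown carry only chloro or bromo at this place. As far as these compounds go, how this assay would respond to an amine or a carboxylic acid there remains open.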